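Shortening the side chain on a cytidine-like sugar core

The source may report more compounds than this note shows. Statements on the series, on what has been measured and on what is new or still open speak of the compounds shown alone.

Among the measured compounds shown here, compound 1, `CCC#C[C@@]1(O)[C@@H](CO)O[C@@H](n2ccc(N)nc2=O)[C@@H]1O`, is the only compound here with a number in a functional assay on KB cells (Homo sapiens), read by MTT assay (on this read-out lower numbers stand for stronger inhibition and higher numbers for weaker inhibition), where compound 1 gives 108000 nM, a weak effect. Compound 2, `C#CC[C@]1(O)[C@@H](CO)OC(n2ccc(N)nc2=O)[C@@H]1O`, reaches only a limit of this assay: in this assay compound 2 gives > 350000 nM, which is a limit and not a number, as noted by the limit of > 350000 nM in this assay, at which 1 of the 2 values shown sits. Compound 3, `C=C[C@@]1(O)[C@@H](CO)O[C@@H](n2ccc(N)nc2=O)[C@@H]1O`, has not been measured in this assay. It differs from compound 1 in one place: vinyl in place of but-1-yn-1-yl on a saturated ring carbon. For the measured compounds named here, no measured pair differing in a single place is available to size such a change, so the expectation rests on the weak reading of compound 1 alone. With both known values sitting at weak or unmeasurable levels, the step from compound 1 to compound 3 is expected to be modest, toward weaker inhibition, as a 1.9-fold higher number from compound 1 to compound 3 (0.27 log units; within the scatter). Compound 3 is therefore estimated at 200000 nM, within a range from 60000 nM to 600000 nM.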

Compound 3, half-maximal inhibitory concentration: 74300 nM
Compound 3: the middle estimate sits 2.7-fold (0.43 log units) above what was measured, within the range that was stated.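

This pair gives the first measured size for a single change on this saturated ring carbon: in this assay, vinyl in place of but-1-yn-1-yl gives a 1.5-fold lower number from compound 1 to compound 3 (0.16 log units; within the scatter). The two compounds therefore cannot be told apart on this read-out, even though the side chain goes from 4 carbons with a triple bond to 2 carbons with a double bond. Nothing shown here bears on why the two readings match.

As far as these compounds go, with only these two groups compared at this position, it remains open whether any group there can produce a step beyond the scatter. A longer chain, an amine or a carboxylic acid on the same ring carbon could each test this, and the pair alone cannot say whether chain length or bond type matters more.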